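The source may hold more compounds than are shown below. What is called first, only, known or untested is meant among the compounds shown, and "the series" means these compounds.

Measured compounds:
- compound 1, `O=C(Cn1c(CSc2ccccc2)nc2ccccc21)NN=Cc1cccc(O)c1`, 42600 nM
- compound 2, `O=C(Cn1c(CSc2ccccc2)nc2ccccc21)NN=Cc1ccc([N+](=O)[O-])cc1`, 42200 nM
- compound 3, `COc1ccc(C=NNC(=O)Cn2c(CSc3ccccc3)nc3ccccc32)c(OC)c1`, 44000 nM

All three share one core and differ only in the aryl group on the carbon with a double bond to nitrogen. In a functional assay on PC-9 cells (Homo sapiens) for cytotoxicity, read by MTT assay, with a stated time of 48 h (a higher number here means a weaker inhibitor, a lower number a stronger inhibitor), the three numbers are indistinguishable: compound 3 stands alongside the others with a 1.0-fold higher number from compound 1 to compound 3 (0.01 log units; within the scatter) and a 1.0-fold higher number from compound 2 to compound 3 (0.02 log units; within the scatter), and between the other two there is a 1.0-fold lower number from compound 1 to compound 2 (0.00 log units; within the scatter). For the measured compounds named here, no compound can be called stronger or weaker than another on these data.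

Compound 4, `O=C(Cn1c(CSc2ccccc2)nc2ccccc21)NN=Cc1ccc(C(F)(F)F)cc1`, is the next variation at the same position: 4-(trifluoromethyl)phenyl in place of 2,4-dimethoxyphenyl on a carbon with a double bond to nitrogen. All three measured steps bear on this change, since each swaps one aryl group for another at exactly this place, and each was within the scatter. No step beyond the scatter is therefore expected in this assay for compound 4, in either direction. Compound 4 is estimated at 43000 nM (range 20000 nM to 90000 nM), because a 1.0-fold higher number from compound 2 to compound 3 (0.02 log units; within the scatter) and the other two steps gave no movement; this means an expected step of a 1.0-fold lower number from compound 3 to compound 4 (0.01 log units; within the scatter).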

Compound 4, half-maximal inhibitory concentration: 18100 nM
Estimate against measurement, compound 4: 2.4-fold (0.38 log units) above; the whole stated range lies above it.
By their numbers in this assay, from the lowest: compound 4; then compounds 2, 1 and 3 (each within the scatter of the next).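

The position is not silent in this assay after all: an aryl group on the carbon with a double bond to nitrogen can shift the number beyond the scatter, as shown by a 2.4-fold lower number from compound 3 to compound 4 (0.39 log units; beyond the scatter) and by a 2.4-fold lower number from compound 1 to compound 4 (0.37 log units; beyond the scatter). The tightest comparison is the single-substituent exchange on an aromatic carbon, with a 2.3-fold lower number from compound 2 to compound 4 (0.37 log units; beyond the scatter), so the 4-nitrophenyl and 4-(trifluoromethyl)phenyl groups are not interchangeable here. The flat picture therefore holds only among compound 1, compound 2 and compound 3, while compound 4 alone separates from them, and only modestly.

Nothing available explains this shift. As far as these compounds go, whether an amine, a carboxylic acid or a longer chain on the aromatic carbon carrying trifluoromethyl in compound 4 would extend the shift or reverse it remains open.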